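Amide variation on a chlorobenzoxazolylthio propanamide series

The compounds below may be only part of what the source reports. "The series", "measured", "known", "first", "only" and "open" are said of these compounds alone.

Measured so far:
- Compound 1 `O=C(CCSc1nc2cc(Cl)ccc2o1)NC1CCCC1`: 11.3 mL/min/g
- Compound 2 `CCN(CC)C(=O)CCSc1nc2cc(Cl)ccc2o1`: 5.9 mL/min/g
- Compound 3 `CN1CCN(C(=O)CCSc2nc3cc(Cl)ccc3o2)CC1`: 1.5 mL/min/g

In an ADME assay on microsomes from liver (Homo sapiens) for metabolic stability, read by LC-MS, using NADPH, with a stated time of 45 min, tested at 0.5 uM (on this read-out higher numbers stand for fast clearance and lower numbers for slow clearance), compound 3 stands lowest of the three, below compound 2 by a 3.9-fold lower number from compound 2 to compound 3 (0.59 log units; beyond the scatter) and below compound 1 by a 7.5-fold lower number from compound 1 to compound 3 (0.88 log units; beyond the scatter). Compound 4 `CC1CCCN1C(=O)CCSc1nc2cc(Cl)ccc2o1` is not yet measured; it differs from compound 3 by 2-methylpyrrolidin-1-yl in place of 4-methylpiperazin-1-yl on a carbonyl carbon. Among the compounds with values here, the step that bears most directly on it is the one from compound 2 to compound 3, where replacing diethylamino by 4-methylpiperazin-1-yl gave a 3.9-fold lower number from compound 2 to compound 3 (0.59 log units; beyond the scatter). Compound 4 removes the 4-methylpiperazin-1-yl again for a group that, like diethylamino, counts no hydrogen-bond acceptor, so a return toward the value of compound 2 is expected, with a 3.7-fold higher number from compound 3 to compound 4 (0.56 log units; beyond the scatter). Compound 4 is therefore estimated at 5.5 mL/min/g, in the range 2.5 mL/min/g to 12 mL/min/g.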

Compound 4, intrinsic clearance in a liver preparation (reported as CLH), per the amount of preparation that the assay uses: 8.5 mL/min/g
Beside the measured number, compound 4's estimate is 1.5-fold (0.19 log units) below it, and the stated range covers the measured number.
By their numbers in this assay, from the lowest: compound 3; then compounds 2, 4 and 1 (each within the scatter of the next).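

In this assay, the low number of compound 3 does not carry over to a 2-methylpyrrolidin-1-yl amide: a 5.7-fold higher number from compound 3 to compound 4 (0.75 log units; beyond the scatter). With a 1.4-fold higher number from compound 2 to compound 4 (0.16 log units; within the scatter) and a 1.3-fold lower number from compound 1 to compound 4 (0.12 log units; within the scatter), the cyclopentylamino, diethylamino and 2-methylpyrrolidin-1-yl amides are not separated, so at this carbonyl carbon only 4-methylpiperazin-1-yl stands apart among the groups shown. No supporting data on hand account for this separation.

As far as these compounds go, it remains open whether the low number depends on the ring nitrogen that carries the methyl or on the six-membered ring itself. Piperidin-1-yl and morpholin-4-yl amides would help to separate these two.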